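The source may report more compounds than this note shows. Statements on the series, on what has been measured and on what is new or still open speak of the compounds shown alone.

The shared core of compound 1 `Cc1ccc(C#Cc2cn(C/C=C\CN3C(=O)c4ccccc4C3=O)c(=O)[nH]c2=O)cc1` carries a triple-bonded aryl group. In a functional assay on MIA PaCa-2 cells (Homo sapiens) for antiproliferative activity, read by MTT assay, with a stated time of 3 days (a lower number here means a stronger inhibitor, a higher number a weaker inhibitor), compound 1 gives only a limit, > 100000 nM. Compound 2 `CCCCCCCCC#Cc1cn(C/C=C\CN2C(=O)c3ccccc3C2=O)c(=O)[nH]c1=O`, with octyl on the triple-bonded carbon, gives 68000 nM in this assay. Compound 3 `O=C1c2ccccc2C(=O)N1C/C=C\Cn1cc(C#Cc2ccc(Br)cc2)c(=O)[nH]c1=O`, with 4-bromophenyl there, again reaches only a limit, > 100000 nM, so compound 3 stands at the weak end of the values shown, alongside compound 1 (the limit of > 100000 nM in this assay, at which 2 of the 3 values shown sit).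

Compound 4 `CCCCCc1ccc(C#Cc2cn(C/C=C\CN3C(=O)c4ccccc4C3=O)c(=O)[nH]c2=O)cc1` differs from compound 3 in one place: pentyl in place of bromo on an aromatic carbon, on an aromatic carbon para to a large group, so that 4-bromophenyl becomes 4-pentylphenyl. The measured steps that touch the same position give little to work with: an at least 1.4-fold lower number from compound 1 to compound 2 (0.16 log units; that floor lies within the scatter) and an at least 1.4-fold higher number from compound 2 to compound 3 (0.16 log units; that floor lies within the scatter), both floors within the scatter, while a step that the two limits leave unreadable from compound 1 to compound 3. Only compound 2, with an aliphatic chain, yields a number at all.

For compound 4 the expected step is an at least 1.1-fold lower number from compound 3 to compound 4 (0.04 log units; that floor lies within the scatter), no more than the scatter allows. The estimate for compound 4 in this assay is 90000 nM, within 30000 nM to 300000 nM.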

Compound 4, half-maximal inhibitory concentration: > 100000 nM
Compound 4 ended at the assay's limit; the forecaster's own chance of this, stated with the estimate: 60%; middle value at least 1.1-fold (0.04 log units) away from the limit.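

In this assay compound 4 gives only a limit, > 100000 nM. Going by these compounds alone, the one comparison that can be read is an at least 1.4-fold higher number from compound 2 to compound 4 (0.16 log units; that floor lies within the scatter), and the steps to the other two limits cannot be read. With pentyl in place of bromo, an aliphatic chain on the aromatic carbon still yields no number, unlike the octyl chain of compound 2 on the triple-bonded carbon, so the aryl compounds shown all remain at the limit: the limit of > 100000 nM in this assay, at which 3 of the 4 values shown sit.

Open, on these data alone, is whether an amine or a carboxylic acid in place of pentyl on the aromatic carbon would give a readable number in this assay. Also open, as far as these compounds go, is whether a chain longer than octyl on the triple-bonded carbon would shift the number of compound 2 by more than the usual scatter.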